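Methyl and methoxy variation on the aryl ring

The source may hold more compounds than are shown below. What is called first, only, known or untested is meant among the compounds shown, and "the series" means these compounds.

Measured so far, in a functional assay on KBVIN cells (Homo sapiens) for antiproliferative activity, read by sulforhodamine B assay, with a stated time of 3 days; a higher number here means that more compound is needed for the effect, a lower number that less compound is needed:
compound 1, `CCC1=C(O)c2c(oc(-c3cccc(C)c3)cc2=O)C(CC)(CC)C1=O`, gives 3.69 uM
compound 2, `CCC1=C(O)c2c(oc(-c3ccc(C)c(C)c3)cc2=O)C(CC)(CC)C1=O`, gives 0.71 uM
compound 3, `CCC1=C(O)c2c(oc(-c3ccc(OC)c(C)c3)cc2=O)C(CC)(CC)C1=O`, gives 0.1 uM

All three share one core and differ only on the aryl ring. Compound 2 differs from compound 1 by methyl in place of hydrogen on an aromatic carbon, which gave a 5.2-fold lower number from compound 1 to compound 2 (0.72 log units; beyond the scatter). Compound 3 differs from compound 1 by methoxy in place of hydrogen on an aromatic carbon, which gave a 37-fold lower number from compound 1 to compound 3 (1.57 log units; beyond the scatter), and from compound 2 the step is a 7.1-fold lower number from compound 2 to compound 3 (0.85 log units; beyond the scatter). Compound 3 therefore stands lowest of the three in this assay, with both steps to it beyond the scatter.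

Compound 4, `CCC1=C(O)c2c(oc(-c3cc(C)c(OC)cc3C)cc2=O)C(CC)(CC)C1=O`, is not yet measured. It differs from compound 3 by methyl in place of hydrogen on an aromatic carbon. This is the same kind of change as that from compound 1 to compound 2, but not the same: there the entering methyl sat ortho to a methyl group and para to a large group, whereas here it sits ortho to a large group, meta to a methoxy group and para to a methyl group. The earlier step rests on a different surrounding, so it is taken only as a rough guide. A step smaller than the earlier one is expected, roughly a 1.5-fold higher number from compound 3 to compound 4 (0.18 log units; within the scatter), because compound 3 already gives 0.1 uM and no ortho methyl to the large group has been measured in this set. Compound 4 is estimated at 0.15 uM, between 0.04 uM and 0.6 uM.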

Compound 4, concentration for half-maximal effect: 7.58 uM
Compound 4: the middle estimate sits 51-fold (1.70 log units) below what was measured, and the stated range ends below it.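

In this assay the added methyl gave a 76-fold higher number from compound 3 to compound 4 (1.88 log units; beyond the scatter) in the direction opposite to the earlier methyl step. The same replacement of hydrogen by methyl on an aromatic carbon therefore does not carry over as one fixed effect from one core to the other in this series, and the two steps differ clearly: the same change on two cores in this assay, a 5.2-fold lower number (0.72 log units; beyond the scatter) from compound 1 to compound 2 and a 76-fold higher number (1.88 log units; beyond the scatter) from compound 3 to compound 4, 390-fold (2.60 log units) apart, beyond the scatter of two such steps.
This does not show why they differ: in compound 4 the entering methyl sits ortho to a large group, meta to a methoxy group and para to a methyl group, and two steps cannot separate the place of the methyl from the rest of the surrounding.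

Still open, on these data alone, is whether a methyl at this same place would give a similar step on an aryl ring without the methoxy group. Also open, as far as these compounds go, is whether the step is particular to methyl or would recur with a fluorine atom, a hydroxyl group or a longer chain such as ethyl at that carbon.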